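A few compounds are considered here, and "the series" means these few. Any claim that something is new, unique, unknown or untested is made for them only; others in the source may bear on it.

Measured so far:
Compound 1, `COCc1nnc(N2CC3(CCc4cc(F)ccc4O3)C2)n1-c1ccc(OC)nc1`, in a functional assay on HEK293 cells for antagonist activity at Oxytocin receptor (Homo sapiens), read by calcium flux, with a stated time of 10 min, in the presence of a further agent that is not named here (a lower number here means a stronger inhibitor, a higher number a weaker inhibitor), gives 401 nM.
Compound 2, `COCc1nnc(C2CCN(Cc3ccc(F)cc3Cl)CC2)n1-c1ccc(OC)nc1`, in this assay gives 2790 nM.
Compound 3, `CCOCc1nnc(N2C[C@@H]3C[C@]3(c3ccc(F)cc3Cl)C2)n1-c1ccc(OC)nc1`, in this assay gives 9.3 nM.

Compound 3 has the lowest number of the three, and its gaps to compound 1 and to compound 2 both lie beyond the scatter. Compound 4, `COc1ccc(-n2c(COCCF)nnc2N2C[C@@H]3C[C@]3(c3ccc(F)cc3Cl)C2)cn1`, differs from compound 3 in one place: fluoro in place of hydrogen on a saturated chain carbon, two bonds along the chain from an oxygen on a saturated carbon. Among the measured compounds shown here, no step between measured compounds matches this change, so nothing measured here sets its size. The change is a small one, so the step from compound 3 to compound 4 in this assay is expected to be small, with no shift beyond the scatter in either direction. Compound 4 is therefore expected to give about 10 nM, within 4 nM to 25 nM, an expected step of a 1.1-fold higher number from compound 3 to compound 4 (0.03 log units; within the scatter).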

Compound 4, half-maximal inhibitory concentration: 44 nM
Compound 4: the middle estimate sits 4.4-fold (0.64 log units) below what was measured; measured number outside the range, above it.
By their numbers in this assay, from the lowest: compound 3; then compound 4; then compound 1; then compound 2.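

Going from ethoxy to 2-fluoroethoxy is not a neutral swap in this assay: it gives a 4.7-fold higher number from compound 3 to compound 4 (0.67 log units; beyond the scatter), so this saturated chain carbon responds to the entry of a single fluoro. Among the compounds shown here, the earlier compounds offered no pair that differed at this position, so this is the first reading of its sensitivity. Nothing available here explains the weakening.

The compounds shown leave open how a hydroxyl, an amine or a longer ether chain would read at this carbon. They also leave open whether a second fluoro there would widen the step.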